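This account rests on a few compounds, and the source may have more. Where it says the series, first, only, none or still open, it means among the compounds named here.

Of the compounds shown here, three sharing one core have been measured in an assay for inhibition of Amine oxidase [flavin-containing] B (Homo sapiens), read by fluorescence, using microsomes, with a stated time of 30 min; a higher number here means a weaker inhibitor, a lower number a stronger inhibitor. Compound 1 `Cc1c(C)c2ccc(OCC3CCN(Cc4ccc(CCO)cc4)CC3)cc2oc1=O` gives 120 nM. Compound 2 `Cc1c(C)c2ccc(OCC3CCN(Cc4cccc(OCCCO)c4)CC3)cc2oc1=O` gives 780 nM, and compound 3 `Cc1c(C)c2ccc(OCC3CCN(CCCCO)CC3)cc2oc1=O` gives 3600 nM. Compound 2 therefore stands second highest of the three numbers, separated from its neighbours by a 6.5-fold higher number from compound 1 to compound 2 (0.81 log units; beyond the scatter) and by a 4.6-fold higher number from compound 2 to compound 3 (0.66 log units; beyond the scatter); the full span of the series is a 30-fold higher number from compound 1 to compound 3 (1.48 log units; beyond the scatter).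

Compound 4 `Cc1c(C)c2ccc(OCC3CCN(Cc4cccc(OCCCO[N+](=O)[O-])c4)CC3)cc2oc1=O` differs from compound 2 by nitro in place of hydrogen on an oxygen on a saturated carbon. Every measured step swaps the entire group on the saturated chain carbon bound to the amine nitrogen in the ring, and those swaps moved the number modestly to largely. Among the compounds with values here, none of them keeps the 3-hydroxypropoxy phenyl group in place and changes only the end of its chain, so no measured step bears directly on this change. With the group otherwise unchanged, the step from compound 2 to compound 4 in this assay is expected to be small, most likely within the scatter, with no direction favoured by the data. The expected outcome is a 1.0-fold lower number from compound 2 to compound 4 (0.02 log units; within the scatter). Compound 4 is estimated at 750 nM, within a range from 250 nM to 2200 nM.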

Compound 4, half-maximal inhibitory concentration: 550 nM
Compound 4: middle estimate off by 1.4-fold (0.13 log units), on the high side; measured number inside the range.
By their numbers in this assay, from the lowest: compound 1; then compounds 4 and 2 (each within the scatter of the next); then compound 3.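

Within the data shown here, this is the first step that keeps the 3-substituted phenyl group in place and alters only the end of its chain, and in this assay it gives a 1.4-fold lower number from compound 2 to compound 4 (0.15 log units; within the scatter) and so stays within the scatter. At this oxygen on a saturated carbon, then, the hydrogen can give way to nitro, which brings 3 heavy atoms, without a measurable loss or gain in this assay, so compound 2 and compound 4 cannot be told apart here. Changes to the whole group on the saturated chain carbon bound to the ring nitrogen, such as a 6.5-fold higher number from compound 1 to compound 2 (0.81 log units; beyond the scatter) in the earlier series, went beyond the scatter, but nothing measured here accounts for the tolerance seen at the chain end.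

A single pair cannot show whether this tolerance extends to other chain ends, such as an amine or a carboxylic acid, or to a longer chain carrying the same nitrooxy group. Going by these compounds, it also remains open whether 2-(nitrooxy)ethyl in place of the 2-hydroxyethyl of compound 1 would behave in the same way on that stronger scaffold.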